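Antiproliferative series: aryl swap at the thiazole carbon

A few compounds are considered here, and "the series" means these few. Any claim that something is new, unique, unknown or untested is made for them only; others in the source may bear on it.

Compound 1 `Cc1c(-c2cc(Cl)cc(Cl)c2)c(C(=O)O)nn1-c1nc(-c2cc(Cl)ccc2F)c(SC(C)C)s1` in a functional assay on BJAB cells (Homo sapiens) for antiproliferative activity, with a stated time of 4 days (a higher number here means that more compound is needed for the effect, a lower number that less compound is needed), gives 4800 nM. Compound 2 `Cc1c(-c2cc(Cl)cc(Cl)c2)c(C(=O)O)nn1-c1nc(-c2ccncc2)c(SC(C)C)s1`, which carries the pyridin-4-yl group instead, is reported in this assay only as "not active" (no number reported), with no number attached, so it stands on the inactive side of compound 1 without a measured gap. Compound 3 `Cc1oncc1-c1nc(-n2nc(C(=O)O)c(-c3cc(Cl)cc(Cl)c3)c2C)sc1SC(C)C` takes the next step: 5-methyl-1,2-oxazol-4-yl in place of pyridin-4-yl on an aromatic carbon. Within the data shown here, no measured step covers this change; given that compound 2 gives "not active" (no number reported), any gain is expected to stay modest, most likely in the direction of weak activity. Compound 3 is estimated at 9000 nM, within 2000 nM to 40000 nM.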

Compound 3, half-maximal effective concentration: > 44000 nM
Compound 3: no number, only a limit; the forecaster's own chance of this, stated with the estimate: 45%; at least 4.8-fold (0.68 log units) between middle value and limit.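

Compound 3 is reported in this assay only as a limit, > 44000 nM. Among these compounds, replacing 5-chloro-2-fluorophenyl with 5-methyl-1,2-oxazol-4-yl on this aromatic carbon gives an at least 9.1-fold higher number from compound 1 to compound 3 (0.96 log units; beyond the scatter), the first step at this position that can be sized at all. A five-membered aromatic ring with 2 hetero atoms thus joins pyridin-4-yl without a numerical value, and compound 2 and compound 3 cannot be ordered against each other.

On these data alone, it remains open whether an unsubstituted phenyl ring at this carbon would keep a measurable value. Also open, as far as these compounds go, is whether an amine on that ring, as in 4-aminophenyl, would do so.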